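Dimethylamino in Place of Methyl on the Shared Core

This account rests on a few compounds, and the source may have more. Where it says the series, first, only, none or still open, it means among the compounds named here.

Of the compounds shown here, two with a shared core have been measured in a functional assay on K562 cells (Homo sapiens), read by MTT assay, with a stated time of 72 h; on this read-out lower numbers stand for stronger inhibition and higher numbers for weaker inhibition. Compound 1 `CN(C)c1ncnc2c1c(-c1ccsc1)cn2[C@@H]1O[C@H](CO)[C@@H](O)[C@H]1O` carries a dimethylamino group, and in this assay compound 1 gives 530 nM. Compound 2 `Cc1ncnc2c1c(-c1cccs1)cn2[C@@H]1O[C@H](CO)[C@@H](O)[C@H]1O` carries a methyl group at the same place. For compound 2 only a limit is known: in this assay compound 2 is reported at > 20000 nM, which is a limit of the assay and not a number. One of the two values shown thus sits at the limit (the limit of > 20000 nM in this assay, at which 1 of the 2 values shown sits), so compound 2 stands at the weak end of what the numbers reveal.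

Compound 3 `CN(C)c1ncnc2c1c(-c1cccs1)cn2[C@@H]1O[C@H](CO)[C@@H](O)[C@H]1O` has not yet been measured. It differs from compound 2 in one place: dimethylamino in place of methyl on an aromatic carbon. For the measured compounds named here, no step between measured compounds is available, so the size of this change cannot be read from a measured pair. Compound 1 nonetheless shows that a dimethylamino group on this core is compatible with a value of 530 nM. The step from compound 2 to compound 3 is expected to be large and toward stronger inhibition, an at least 13-fold lower number from compound 2 to compound 3 (1.12 log units; beyond the scatter). Compound 3 is estimated at 1500 nM, within a range from 300 nM to 8000 nM.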

Compound 3, half-maximal inhibitory concentration: > 20000 nM
Compound 3: a limit, no number; the forecaster's own chance of this, stated with the estimate: 10%; middle value at least 13-fold (1.12 log units) from the limit.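

Dimethylamino at this place does not by itself carry the activity in this assay: compound 3, which holds that group, is reported at > 20000 nM, and this value is a limit of the assay and not a number. With dimethylamino held constant on the shared core, thiophen-2-yl in place of thiophen-3-yl gives an at least 37-fold higher number from compound 1 to compound 3 (1.57 log units; beyond the scatter), so the value of compound 1 is tied to the thiophen-3-yl group as well as to the dimethylamino group. The step between the methyl and dimethylamino compounds cannot be read, with both of its ends at a limit, and the weak end now holds most of the compounds shown: the limit of > 20000 nM in this assay, at which 2 of the 3 values shown sit.

The compounds shown leave open how methyl at this place would read alongside thiophen-3-yl, a pairing that could give a readable step against compound 1. They also leave open whether another group on this aromatic carbon, such as a primary amine or a methoxy group, would bring a thiophen-2-yl compound away from the limit.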